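The source may hold more compounds than are shown below. What is called first, only, known or untested is meant among the compounds shown, and "the series" means these compounds.

Measured compounds:

Compound 1, `CC1(c2ccccc2)CCCN(C(=O)Nc2ccncc2)C1`. In an assay for inhibition of epoxide hydrolase 1 (Homo sapiens), using microsomes (on this read-out higher numbers stand for weaker inhibition and lower numbers for stronger inhibition), compound 1 gives > 100000 nM, which is a limit of the assay rather than a measured number.

Compound 2, `O=C(O)CC1(c2ccccc2)CCCN(C(=O)Nc2ccc(Cl)cc2)C1`. In this assay compound 2 gives > 100000 nM, again a limit and not a number.

For the measured compounds named here, compound 2 therefore cannot be ranked against anything: its own value is only a limit, and the one other value shown is a limit as well, so both sit at the limit of > 100000 nM in this assay, at which 2 of the 2 values shown sit. Nothing in these two results says how far apart the compounds really are.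

Compound 3, `O=C(Nc1ccc(Cl)cc1)N1CCCC(CCCO)(c2ccccc2)C1`, differs from compound 2 in one place: 2-hydroxyethyl in place of carboxy on a saturated chain carbon bound to a saturated ring carbon. An acid group is exchanged for an alcohol-bearing chain of the same length class, while the urea and the phenyl-bearing ring are kept.

Going by the values given here, no pair of measured compounds that differ in a single place is available, so there is no measured step to lean on for this change. With compound 2 giving only a limit, the expectation for compound 3 is no step beyond the usual scatter, and a number no higher from compound 2 to compound 3 (the limit leaves the size open) is the step my estimate implies. Compound 3 is expected to come out near 100000 nM, within a range of 20000 nM to 300000 nM, most likely reported again as a limit.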

Compound 3, half-maximal inhibitory concentration: > 100000 nM
Compound 3 was reported as a limit; the forecaster's own chance of this, stated with the estimate: 70%; the middle value sits exactly at the limit.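

In this assay compound 3 gives > 100000 nM and this is again a limit of the assay, not a number. No step can be read between compound 2 and compound 3, because neither result is an actual number: the limit of > 100000 nM in this assay, at which 3 of the 3 values shown sit.

The compounds shown leave open how strongly each one inhibits the enzyme, and whether replacing carboxy with 2-hydroxyethyl changes that inhibition at all.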